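Working notes on the fluoro analogue, compound 4

The source may report more compounds than this note shows. Statements on the series, on what has been measured and on what is new or still open speak of the compounds shown alone.

Measured so far in a functional assay on HT-29 cells (Homo sapiens) for inhibition, read by MTT assay, with a stated time of 48 h; a higher number here means a weaker inhibitor, a lower number a stronger inhibitor:
Compound 1 `Cc1ccc(NC(=S)NC(=O)c2ccc(OCc3cccc(Cl)c3Cl)cc2)cc1-c1nc2ccccc2[nH]1` gives 63700 nM.
Compound 2 `Cc1ccc(NC(=O)NC(=O)c2ccc(OCc3ccccc3)cc2)cc1-c1nc2ccccc2[nH]1` gives 16400 nM.
Compound 3 `Cc1ccc(NC(=O)NC(=O)c2ccc(OCc3cccc(C(F)(F)F)c3)cc2)cc1-c1nc2ccccc2[nH]1` gives 3520 nM.

Compound 3 stands lowest of the three numbers in this assay. Among the measured compounds shown here, its nearest neighbour is compound 2, and the only single-change step available in this set is a 4.7-fold lower number from compound 2 to compound 3 (0.67 log units; beyond the scatter), a move in the same direction as the change now at hand, yet not the same change. Compound 1, a thiourea bearing a dichlorinated benzyl ether, differs from compound 3 in more than one place, so its value says nothing directly about the step to compound 4.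

Compound 4 `Cc1ccc(NC(=O)NC(=O)c2ccc(OCc3cccc(F)c3)cc2)cc1-c1nc2ccccc2[nH]1` has not yet been measured. The change from compound 3 reads: fluoro in place of trifluoromethyl on an aromatic carbon. For the measured compounds named here, no measured pair shows fluoro against trifluoromethyl, so the expectation leans on compound 2 and compound 3 only: with hydrogen the number was higher, with trifluoromethyl lower, and a single fluorine is taken to lie between those two, closer to compound 3 than to compound 2. The step is therefore expected to be a modest rise, a 2.3-fold higher number from compound 3 to compound 4 (0.36 log units; beyond the scatter), possibly within the scatter. Compound 4 is estimated at 8000 nM in this assay, with a range from 3000 nM to 22000 nM.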

Compound 4, half-maximal inhibitory concentration: 38200 nM
Estimate against measurement, compound 4: 4.8-fold (0.68 log units) below; the whole stated range lies below it.
By their numbers in this assay, from the lowest: compound 3; then compound 2; then compounds 4 and 1 (each within the scatter of the next).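

In this assay, the change from trifluoromethyl to fluoro at this aromatic carbon gives an 11-fold higher number from compound 3 to compound 4 (1.04 log units; beyond the scatter), so a single fluorine does not retain the gain seen with trifluoromethyl. Fluoro in place of hydrogen gives a 2.3-fold higher number from compound 2 to compound 4 (0.37 log units; beyond the scatter), opposite in direction to a 4.7-fold lower number from compound 2 to compound 3 (0.67 log units; beyond the scatter), so the three compounds that differ only at this place do not fall in a graded order running from hydrogen through fluoro to trifluoromethyl: both fluorine-bearing groups move the number away from the hydrogen compound, but on opposite sides of it. No measurement at hand bears on the reason for this split.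

The compounds shown leave open whether the lower number is particular to trifluoromethyl or is shared by other groups at this place, such as a methoxy, a nitrile or a single chlorine. They also leave open whether the same difference between fluoro and trifluoromethyl would appear on the thiourea form of the series, since compound 1 differs from these compounds in more than one place.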